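Tertiary amide at the acrylamide of a fused bicyclic series

The compounds below may be only part of what the source reports. "The series", "measured", "known", "first", "only" and "open" are said of these compounds alone.

Measured so far:
compound 1 `O=C(/C=C1\CCc2c(F)cc(F)cc21)NCCO`, 100 mg/kg
compound 2 `NC(=O)/C=C1/CCc2ccc(F)cc21`, 64 mg/kg
compound 3 `CCNC(=O)/C=C1\CCc2ccc(F)cc21`, 70 mg/kg

In a functional assay on the whole organism with Mus musculus as the target (on this read-out lower numbers stand for an effect already at smaller amounts and higher numbers for an effect only at larger amounts of compound), compound 1 gives 100 mg/kg, compound 2 gives 64 mg/kg and compound 3 gives 70 mg/kg. Compound 3 stands within the scatter of both other compounds: its nearest neighbour is compound 2 and its furthest is compound 1, and neither gap exceeds the usual scatter of repeated measurements. Among the compounds with values here, on these three numbers no compound separates from the others, and no step between compounds differing in a single place is available from the measured set.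

Compound 4 `CN(C)C(=O)/C=C1\CCc2ccc(F)cc21` is the next compound to be measured in this assay. It differs from compound 3 in one place: dimethylamino in place of ethylamino on a carbonyl carbon. The amide hydrogen of compound 3 is thus absent in compound 4, the atom count being unchanged.

Within the data shown here, no measured step bears on a change of this kind, so the expectation rests on the spread of the three numbers alone. Compound 4 is expected to give 80 mg/kg, with a range from 40 mg/kg to 160 mg/kg. The estimated step of a 1.1-fold higher number from compound 3 to compound 4 (0.06 log units; within the scatter) is expected to stay within the scatter, with no clear direction.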

Compound 4, dose for half-maximal effect: > 100 mg/kg
Compound 4: a limit, no number (the forecaster's own chance of this, stated with the estimate: 10%); middle value at least 1.2-fold (0.09 log units) from the limit.
By their numbers in this assay, from the lowest: compounds 2, 3 and 1 (each within the scatter of the next).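

Compound 4 gives > 100 mg/kg in this assay, and this value is a limit of the assay, not a number. Going by these compounds, this provides the series' first step between compounds that differ in one place: dimethylamino in place of ethylamino on a carbonyl carbon gives an at least 1.4-fold higher number from compound 3 to compound 4 (0.15 log units; that floor lies within the scatter), so compound 4 does not separate from compound 3 on what can be read, and the true size of the step remains unknown. The change removes the amide hydrogen while keeping the same atoms, and it takes the read-out of this position to the edge of the measurable range, the only reading available for a tertiary amide here: the limit of > 100 mg/kg in this assay, at which 1 of the 4 values shown sits.

A single step cannot show whether the absent amide hydrogen or the second methyl on the nitrogen accounts for the result, and a limit cannot show how far the step really runs. A pyrrolidine amide or a morpholine amide on the same core, or a longer chain such as n-propyl on the secondary amide, would show how far this position tolerates change.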